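A few compounds are considered here, and "the series" means these few. Any claim that something is new, unique, unknown or untested is made for them only; others in the source may bear on it.

Working notes on the series. In an ADME assay on HEK293 cells (Homo sapiens) for cytotoxicity (a higher number here means a weaker inhibitor, a lower number a stronger inhibitor), compound 1 `CCCCCCCCCCCCCCNC(=O)[C@H](CO)/N=C/c1cccc(OC)c1` gives 77300 nM, compound 2 `CCCCCCCCCCCCCCNC(=O)[C@H](CO)/N=C/c1ccccc1OC` gives 79200 nM and compound 3 `CCCCCCCCCCCCCCNC(=O)[C@H](CO)/N=C/c1ccccc1Cl` gives 94900 nM. Compound 3 stands level with the other two, as all three values lie within the scatter of each other.

Next is compound 4 `CCCCCCCCCCCCCCNC(=O)[C@H](CO)/N=C/c1cccc([N+](=O)[O-])c1`, which differs from compound 3 as follows: 3-nitrophenyl in place of 2-chlorophenyl on a carbon with a double bond to nitrogen. For the measured compounds named here, the 3-nitrophenyl group has no measured precedent here. The closest evidence is the changes of group on that same carbon: a 1.0-fold higher number from compound 1 to compound 2 (0.01 log units; within the scatter), a 1.2-fold higher number from compound 1 to compound 3 (0.09 log units; within the scatter) and a 1.2-fold higher number from compound 2 to compound 3 (0.08 log units; within the scatter), each within the scatter. In this assay, a step no larger than the scatter and with no set direction is therefore expected. The estimated step is a 1.2-fold lower number from compound 3 to compound 4 (0.06 log units; within the scatter). Compound 4 is estimated at 82000 nM, with an expected range of 45000 nM to 130000 nM.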

Compound 4, half-maximal inhibitory concentration: 82700 nM
Beside the measured number, compound 4's estimate is 1.0-fold (0.00 log units) below it, within the range that was stated.
By their numbers in this assay, from the lowest: compounds 1, 2, 4 and 3 (each within the scatter of the next).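

In this assay the 3-nitrophenyl group reads level with 2-chlorophenyl (a 1.1-fold lower number from compound 3 to compound 4 (0.06 log units; within the scatter)) and with 2-methoxyphenyl (a 1.0-fold higher number from compound 2 to compound 4 (0.02 log units; within the scatter)). Against 3-methoxyphenyl the reading is equally flat (a 1.1-fold higher number from compound 1 to compound 4 (0.03 log units; within the scatter)), so the first nitro group on this carbon extends the flat reading to four compounds. Nothing on hand accounts for this flatness.

Still open, as far as these compounds go, is whether an amine or a carboxylic acid on the aromatic ring would move the number. Also open, from the compounds shown here alone, is what a shorter chain would do in place of the long chain of the shared core.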